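The source may report more compounds than this note shows. Statements on the series, on what has been measured and on what is new or still open speak of the compounds shown alone.

Working notes on the series around compound 1 `CC(C)C[C@H](NC(=O)c1ccc(Cl)c(Cl)c1)C(=O)N[C@H]1CCN(Cc2ccc(OCCCN(C)C)cc2)C1`. In an assay on HEK293 cells for binding affinity to Urotensin-2 receptor (Homo sapiens), read by radioligand binding (a higher number here means a weaker inhibitor, a lower number a stronger inhibitor), compound 1 gives 126 nM, the lowest of the three numbers in hand. Compound 2 `CC(C)C[C@H](NC(=O)c1ccccc1)C(=O)N[C@H]1CCN(Cc2ccc(OCCCN(C)C)cc2)C1` gives 501 nM in this assay, and compound 3 `CC(=O)N[C@@H](CC(C)C)C(=O)N[C@H]1CCN(Cc2ccc(OCCCN(C)C)cc2)C1` gives 2510 nM. Every step measured so far concerns the group on the carbonyl carbon: a 4.0-fold higher number from compound 1 to compound 2 (0.60 log units; beyond the scatter), a 20-fold higher number from compound 1 to compound 3 (1.30 log units; beyond the scatter) and a 5.0-fold higher number from compound 2 to compound 3 (0.70 log units; beyond the scatter). Compound 4 `CC(C)[C@H](NC(=O)c1ccc(Cl)c(Cl)c1)C(=O)N[C@H]1CCN(Cc2ccc(OCCCN(C)C)cc2)C1` differs from compound 1 at another place: isopropyl in place of isobutyl on a saturated chain carbon bound to an amide-type nitrogen and a carbonyl carbon. Within the data shown here, none of the measured steps touches this part of the shared core, so none of them bears directly on the change, and the expected size of the step from compound 1 to compound 4 in this assay rests on the change itself, which is small in what it removes and adds. The expectation is a step of modest size at most, more likely toward a higher number than a lower one, and possibly none beyond the scatter. Compound 4 is therefore estimated at 220 nM, with a range from 70 nM to 700 nM, which means an expected step of a 1.7-fold higher number from compound 1 to compound 4 (0.24 log units; within the scatter).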

Compound 4, inhibition constant: 794 nM
The estimate for compound 4 lay 3.6-fold (0.56 log units) below the measured number; measured number above the stated range.
By their numbers in this assay, from the lowest: compound 1; then compounds 2 and 4 (each within the scatter of the next); then compound 3.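

Isopropyl in place of isobutyl on a saturated chain carbon bound to an amide-type nitrogen and a carbonyl carbon gives a 6.3-fold higher number from compound 1 to compound 4 (0.80 log units; beyond the scatter) in this assay and shows that the group on the carbonyl carbon is not the only part of the series that responds. With the 3,4-dichlorophenyl group held constant, isobutyl gives the lower number of the two groups compared at this place, so even this small exchange moves the number beyond the scatter. Nothing at hand explains the size of this step.

On these data alone, whether a benzyl group or a longer chain such as n-hexyl would lower or raise the number at this place remains open. Also open, as far as these compounds go, is whether the same exchange carries a similar step when phenyl or methyl stands on the carbonyl carbon.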